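The compounds below may be only part of what the source reports. "The series", "measured", "known", "first", "only" and "open" are said of these compounds alone.

Compound 3 `COc1ccc(-c2cc(CN(c3nc4ccc(F)cc4s3)c3nc4ccc(OC)cc4s3)on2)cc1` gives 32400 nM in a functional assay on MCF7 cells (Homo sapiens) for antiproliferative activity, read by MTT assay (a higher number here means a weaker inhibitor, a lower number a stronger inhibitor), the highest of the three numbers measured. Compound 1 `COc1ccc2nc(N(Cc3cc(-c4ccc(SC(F)(F)F)cc4)no3)c3nc4ccc(F)cc4s3)sc2c1` gives 14100 nM, and compound 2 `COc1ccc2nc(N(Cc3cc(-c4ccc(OC(F)(F)F)cc4)no3)c3nc4ccc(F)cc4s3)sc2c1` gives 17400 nM. Compound 4 `COc1ccc2nc(N(Cc3cc(-c4cc(OC)c(OC)c(OC)c4)no3)c3nc4ccc(F)cc4s3)sc2c1` differs from compound 3 by 3,4,5-trimethoxyphenyl in place of 4-methoxyphenyl on an aromatic carbon. All three measured steps alter the substituent on this same aromatic ring: a 2.3-fold higher number from compound 1 to compound 3 (0.36 log units; beyond the scatter), a 1.9-fold higher number from compound 2 to compound 3 (0.27 log units; within the scatter) and a 1.2-fold higher number from compound 1 to compound 2 (0.09 log units; within the scatter). Each of these is small, and none concerns adding two further methoxy groups, so in this assay only a modest step, in either direction or none beyond the scatter, is expected for compound 4: a 1.1-fold lower number from compound 3 to compound 4 (0.03 log units; within the scatter). Compound 4 is therefore estimated at 30000 nM, with a range from 10000 nM to 90000 nM.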

Compound 4, half-maximal inhibitory concentration: 26600 nM
Compound 4: the middle estimate sits 1.1-fold (0.05 log units) above what was measured, and the stated range covers the measured number.
By their numbers in this assay, from the lowest: compounds 1, 2, 4 and 3 (each within the scatter of the next, the first and the last beyond it).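

In this assay, the two further methoxy groups of 3,4,5-trimethoxyphenyl change little at this position, with a 1.2-fold lower number from compound 3 to compound 4 (0.09 log units; within the scatter). Compound 4 also stays within the scatter of the other two compounds, with a 1.5-fold higher number from compound 2 to compound 4 (0.18 log units; within the scatter) and a 1.9-fold higher number from compound 1 to compound 4 (0.28 log units; within the scatter), so this larger substituent, carrying more hydrogen-bond acceptors, is tolerated without a clear loss or gain. Nothing available explains this result. On these data alone, it remains open whether an amine or a carboxylic acid on this phenyl ring, or a longer chain in place of a methoxy group, would shift the number beyond the scatter.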